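The compounds below may be only part of what the source reports. "The series", "measured", "known", "first", "only" and "open" are said of these compounds alone.

Within the data shown here, in a functional assay on the whole organism (blood, strain albino) with Mus musculus as the target, with stated times of 6 days and 3 h, at a dose of 1 mmol/kg by the oral route (on this read-out lower numbers stand for less inhibition and higher numbers for more inhibition at the one dose given (going by the name of the read-out)), compound 2 `Cc1cc(C(=O)O)nn1-c1ccc(S(=O)(=O)N2CCC(=O)N(Cc3ccccc3)C2=S)cc1` gives 16%, the second highest of the three numbers measured so far. Compound 3 `Cc1cc(C)n(-c2ccc(S(=O)(=O)N3CCC(=O)N(Cc4ccccc4)C3=S)cc2)n1` gives 18%, and the step of a number 2 percentage points higher from compound 2 to compound 3 (within the scatter) lies within the scatter. Compound 1 `CCCCN1C(=O)CCN(S(=O)(=O)c2ccc(-n3nc(C)cc3C)cc2)C1=S` gives 1%, and the step of a number 17 percentage points higher from compound 1 to compound 3 (beyond the scatter) is beyond the scatter. Compound 4 `Cc1cc(C(=O)O)nn1-c1ccc(S(=O)(=O)N2CCC(=O)N(c3ccccc3)C2=S)cc1` is the next case: phenyl in place of benzyl on an amide-type nitrogen in a ring. Among the measured compounds shown here, no measured step exchanges benzyl for phenyl at this nitrogen; the step of a number 17 percentage points higher from compound 1 to compound 3 (beyond the scatter) is the only one that changes the group on that nitrogen, and there phenyl replaced propyl rather than benzyl. A step no larger than the scatter, in no fixed direction, is therefore expected, and a number 1 percentage points lower from compound 2 to compound 4 (within the scatter) is the estimate. For compound 4 the value expected in this assay is 15%, with a range from 3% to 35%.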

Compound 4, a percentage reported as inhibition, in the whole organism at one dose (the size of the read-out at that dose, not a potency): 1%
Compound 4: middle estimate off by 14 percentage points, on the high side; the whole stated range lies above it.
By their numbers in this assay, from the lowest: compounds 1 and 4 (each within the scatter of the next); then compounds 2 and 3 (each within the scatter of the next).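

At the amide-type nitrogen in a ring, benzyl and phenyl are not interchangeable in this assay: the change gives a number 15 percentage points lower from compound 2 to compound 4 (beyond the scatter). The earlier step on this nitrogen came with methyl on the aromatic carbon, whereas this one shows that the group here also matters with carboxy in that place. No measurement at hand accounts for the step.

Open, as far as these compounds go, is whether phenyl in place of benzyl gives a similar step with methyl instead of carboxy. Also open, from the compounds shown here alone, is how a longer chain carrying the phenyl, such as phenylethyl, would read on this nitrogen.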